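Adding a second methoxy to compound 3

This account rests on a few compounds, and the source may have more. Where it says the series, first, only, none or still open, it means among the compounds named here.

Measured values in a functional assay on MGC-803 cells (Homo sapiens) for cytotoxicity, read by MTT assay, with a stated time of 72 h; on this read-out lower numbers stand for stronger inhibition and higher numbers for weaker inhibition:
- compound 1 `O=C1C(=Cc2ccc(Cl)cc2)C(=O)N(c2ccc(Cl)cc2)N1c1ccc(Cl)cc1`: 32600 nM
- compound 2 `COc1ccc(C=C2C(=O)N(c3ccc(Cl)cc3)N(c3ccc(Cl)cc3)C2=O)cc1`: > 128000 nM (a limit of the assay, not a number)
- compound 3 `COc1cccc(C=C2C(=O)N(c3ccc(Cl)cc3)N(c3ccc(Cl)cc3)C2=O)c1`: 26600 nM

Compound 3 cannot be separated from compound 1 on these data: a 1.2-fold lower number from compound 1 to compound 3 (0.09 log units; within the scatter). Its gap to the limit value is beyond the scatter: an at least 4.8-fold lower number from compound 2 to compound 3 (0.68 log units; beyond the scatter).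

Compound 4 `COc1cccc(C=C2C(=O)N(c3ccc(Cl)cc3)N(c3ccc(Cl)cc3)C2=O)c1OC` is the next entry, and the change is methoxy in place of hydrogen on an aromatic carbon. In words, this is methoxy in place of hydrogen on an aromatic carbon, taking 3-methoxyphenyl to 2,3-dimethoxyphenyl.

Going by the values given here, no measured step makes this same change, so the evidence is indirect. Methoxy in place of chloro gave an at least 3.9-fold higher number from compound 1 to compound 2 (0.59 log units; beyond the scatter), which shows that a methoxy can matter in this series. Compound 4 keeps the 3-methoxyphenyl arrangement of compound 3 at 26600 nM, so no step beyond the scatter in this assay is expected, with a slight lean towards a higher number. The expected step is a 1.5-fold higher number from compound 3 to compound 4 (0.18 log units; within the scatter). For compound 4 the estimated value is 40000 nM, with an expected range from 10000 nM to 120000 nM.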

Compound 4, half-maximal inhibitory concentration: 29600 nM
Estimate against measurement, compound 4: 1.4-fold (0.13 log units) above; measured number inside the range.
By their numbers in this assay, from the lowest: compounds 3, 4 and 1 (each within the scatter of the next). At a limit, above all of these: compound 2.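

In this assay the aromatic carbon ortho to a large group and ortho to a methoxy group accepts methoxy in place of hydrogen with no change that can be read (a 1.1-fold higher number from compound 3 to compound 4 (0.05 log units; within the scatter)), the first direct measure of this change in the series. The 2,3-dimethoxyphenyl of compound 4 also cannot be separated from the 4-chlorophenyl of compound 1 (a 1.1-fold lower number from compound 1 to compound 4 (0.04 log units; within the scatter)), so this aromatic group joins the two others that sit within the scatter of each other. The value of compound 2 is a limit of the assay and not a number, yet the step to compound 4 lies beyond the scatter (an at least 4.3-fold lower number from compound 2 to compound 4 (0.63 log units; beyond the scatter)), which shows that a methoxy count of two on this ring does not by itself bring the read-out to that limit.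

From the compounds shown here alone, whether this position tolerates methoxy without the neighbouring 3-methoxy group, or on the 4-methoxyphenyl of compound 2, stays open. So does the effect of a hydroxy, an amine or a carboxylic acid at this position, since only hydrogen and methoxy appear here.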